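A few compounds are considered here, and "the series" means these few. Any claim that something is new, unique, unknown or untested is made for them only; others in the source may bear on it.

Working notes on the series in an ADME assay on H1-HeLa cells (Homo sapiens) for cytotoxicity, read by MTT assay, with a stated time of 3 days; a higher number here means that more compound is tolerated, a lower number that less compound is tolerated. Compound 1 `CCOC(=O)c1cc2ccc(Oc3ccnc(C(=O)NC)c3)cc2s1` in this assay reaches only the assay limit, > 100000 nM. Compound 2 `CNC(=O)c1cc(Oc2ccc3cc(C(=O)OC(C)C)sc3c2)ccn1` in this assay gives 45700 nM. The change from compound 1 to compound 2 is methyl in place of hydrogen on a saturated chain carbon bound to an oxygen next to a carbonyl group and a saturated chain carbon, and it brings an at least 2.1-fold lower number from compound 1 to compound 2 (0.34 log units; beyond the scatter); because compound 1 sits at the limit of > 100000 nM in this assay, at which 1 of the 3 values shown sits, only the floor of that step is known and its true size is open. Compound 3 `CCOC(=O)c1ccc2ccc(Oc3ccnc(C(=O)NC)c3)cc2c1` carries a different core from compound 1; the difference between the two cores is not broken down here. In this assay compound 3 gives 20800 nM, the lowest number among the measured compounds. Compound 4 `CNC(=O)c1cc(Oc2ccc3ccc(C(=O)OC(C)C)cc3c2)ccn1` is compound 3 with methyl in place of hydrogen on a saturated chain carbon bound to an oxygen next to a carbonyl group and a saturated chain carbon, the same change as that between compound 1 and compound 2. A step of similar direction and modest size is expected in this assay, resting on the step of an at least 2.1-fold lower number from compound 1 to compound 2 (0.34 log units; beyond the scatter), while noting that it was measured from a limit and so its size is uncertain. The expected step from compound 3 to compound 4 is a 2.1-fold lower number from compound 3 to compound 4 (0.32 log units; beyond the scatter). Compound 4 is expected to give 10000 nM in this assay, estimated between 4000 nM and 25000 nM.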

Compound 4, half-maximal cytotoxic concentration: 13800 nM
For compound 4 the middle estimate is 1.4-fold (0.14 log units) below the measured one; the range from low to high includes it.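

In this assay, the change from ethoxycarbonyl to isopropoxycarbonyl on the core of compound 3 gives a 1.5-fold lower number from compound 3 to compound 4 (0.18 log units; within the scatter), so on this core the step cannot be told apart from the scatter of repeated measurements. The pair on the core of compound 3 therefore gives no firm support for a step that carries over from the core of compound 1, and it does not show that the change fails to carry over either; the comparison of the two steps stays unresolved: the same change on two cores in this assay, an at least 2.1-fold lower number (0.34 log units; beyond the scatter) from compound 1 to compound 2 and a 1.5-fold lower number (0.18 log units; within the scatter) from compound 3 to compound 4; the limit leaves it open whether they differ For compound 1, the reading of > 100000 nM is a limit of the assay and not a number, so the step that starts from it has only a known floor: the limit of > 100000 nM in this assay, at which 1 of the 4 values shown sits.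

The compounds shown leave open how a carboxylic acid or a chain longer than isopropoxy, carried in the same place, would read in this assay on either core. They also leave open whether the change from ethoxycarbonyl to isopropoxycarbonyl would give a step beyond the scatter on a third core.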